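Compound 4: A Methyl Group Gives Way to Hydrogen

The source may report more compounds than this note shows. Statements on the series, on what has been measured and on what is new or still open speak of the compounds shown alone.

In a functional assay on HeLa cells (Homo sapiens) for cytotoxicity, read by XTT assay, with a stated time of 72 h (on this read-out higher numbers stand for weaker inhibition and lower numbers for stronger inhibition), compound 1 (`CC(C)=CCC/C=C(\C)Cc1c(O)cc(O)c2c(=O)cc(-c3ccccc3)oc12`) gives 19000 nM as a measured value. Compound 2 (`C=C1CC[C@H]2C(C)(C)CCC[C@]2(C)[C@H]1CC/C(C)=C/COc1cc(O)c2c(=O)c(O)c(-c3ccc(OC)cc3)oc2c1`) shows > 100000 nM as a limit and not a number. Compound 3 (`CCCCCCCCCCCCCCCCCCOc1cc(O)c(C(C)=O)c(O)c1`) shows > 100000 nM as a limit too. Compound 2 thus stands at the limit of > 100000 nM in this assay, at which 2 of the 3 values shown sit, and has no exact position on the scale. Compound 4 (`C=C1CC[C@H]2C(C)(C)CCC[C@]2(C)[C@H]1CC/C(C)=C/COc1cc(O)c2c(=O)c(O)c(-c3ccc(O)cc3)oc2c1`) differs from compound 2 (hydrogen in place of methyl on an oxygen on an aromatic ring) by hydrogen in place of methyl on an oxygen on an aromatic ring. For the measured compounds named here, no measured step bears on this change, so only a modest move towards stronger inhibition in this assay is expected, possibly none beyond the scatter. The expected change is an at least 1.4-fold lower number from compound 2 to compound 4 (0.15 log units; that floor lies within the scatter) by this estimate. For compound 4 the estimated value is 70000 nM within an expected range from 20000 nM to 200000 nM for now.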

Compound 4, half-maximal inhibitory concentration: > 100000 nM
Compound 4 ended at the assay's limit; the forecaster's own chance of this, stated with the estimate: 55%; middle value at least 1.4-fold (0.15 log units) from the limit.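

For the compounds shown here, compound 2 and compound 4 both rest at a limit and not at a number, so no step between them can be read: the limit of > 100000 nM in this assay, at which 3 of the 4 values shown sit.

The compounds shown leave open whether in this assay hydrogen in place of methyl on an oxygen on an aromatic ring changes inhibition at all.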